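A few compounds are considered here, and "the series" means these few. Any claim that something is new, unique, unknown or untested is made for them only; others in the source may bear on it.

Of the compounds shown here, two have so far been measured in an assay on cell membranes for binding affinity to Neuronal acetylcholine receptor; alpha4/beta2 (Rattus norvegicus), read by radioligand binding; on this read-out higher numbers stand for weaker inhibition and lower numbers for stronger inhibition. Compound 1 `Clc1cncc(N2CCNCC2)c1` gives 310 nM, while compound 2 `NC(=O)c1cncc(N2CCCNCC2)c1` gives 20 nM, the lowest of the two numbers and well beyond the scatter from compound 1. Compound 3 `OCCOc1cncc(N2CCCNCC2)c1` has not yet been measured; it keeps the core of compound 2 and differs only by 2-hydroxyethoxy in place of carbamoyl on an aromatic carbon. For the measured compounds named here, no measured pair shows a change of this kind, so its size is uncertain; a modest rise, at or a little beyond the scatter, is expected, as the step of a 2.5-fold higher number from compound 2 to compound 3 (0.40 log units; beyond the scatter). In this assay compound 3 is expected to give 50 nM, with a range from 10 nM to 250 nM.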

Compound 3, half-maximal inhibitory concentration: 1.8 nM
The estimate for compound 3 lay 28-fold (1.44 log units) above the measured number; measured number outside the range, below it.
By their numbers in this assay, from the lowest: compound 3; then compound 2; then compound 1.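

On an aromatic carbon two atoms from the ring nitrogen, 2-hydroxyethoxy in place of carbamoyl gives an 11-fold lower number from compound 2 to compound 3 (1.05 log units; beyond the scatter). The carbamoyl group is therefore not needed at this position for a low number, and a chain joined to the ring through oxygen does better here. For the compounds shown here, nothing measured so far gives a reason for this drop.

On these data alone, it remains open whether the hydroxyl at the chain's end matters, which a plain methoxy or ethoxy group at this position would test. As far as these compounds go, how a longer chain, such as 3-hydroxypropoxy, or an amine would behave here also remains open.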